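A few compounds are considered here, and "the series" means these few. Any claim that something is new, unique, unknown or untested is made for them only; others in the source may bear on it.

Compound 1 `O=c1c(O)c(O)oc2ccc(Cl)cc12` has been measured in a functional assay for inhibition, with Homo sapiens as the target (on this read-out lower numbers stand for stronger inhibition and higher numbers for weaker inhibition), and in that test compound 1 gives 780000 nM. Among the three compounds measured, this is the only actual number. Compound 2 `O=C1C(O)=C(O)OC12CCCC2` reaches only a limit of the assay, > 4000000 nM. Compound 3 `O=C1C(O)=C(O)OC12CCCCC2` likewise reaches only a limit, > 4000000 nM. Among the compounds with values here, compound 1 therefore stands as the single compound with a numerical value, while the other two sit at the limit of > 4000000 nM in this assay, at which 2 of the 3 values shown sit. Compound 4 `O=c1c(O)c(O)oc2ccc(O)cc12` has not yet been measured. It differs from compound 1 by hydroxy in place of chloro on an aromatic carbon. Within the data shown here, no step between two measured compounds differing in one place is available, so the size of such a change is not known from these data. The expectation is a step toward weaker inhibition in this assay, of about the scatter of the method. Compound 4 is expected to give 1200000 nM, within a range from 300000 nM to 4000000 nM. The step from compound 1 to compound 4 is thus estimated at a 1.5-fold higher number from compound 1 to compound 4 (0.19 log units; within the scatter).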

Compound 4, half-maximal inhibitory concentration: 3510000 nM
Compound 4: middle estimate off by 2.9-fold (0.47 log units), on the low side; the range from low to high includes it.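

In this assay, within the data shown here, the first step that can be read on this core is a 4.5-fold higher number from compound 1 to compound 4 (0.65 log units; beyond the scatter), so hydroxy in place of chloro on this aromatic carbon moves the result toward weaker inhibition by more than the scatter. The earlier compounds shown here could not show this, as no two of them differed in one place and only compound 1 had a number. Compound 4 now gives a second number, close to the top of what the test reports, where compound 2 and compound 3 stand at a limit rather than a number: the limit of > 4000000 nM in this assay, at which 2 of the 4 values shown sit.

A single swap cannot tell whether chloro favours inhibition or hydroxy disfavours it, and a plain hydrogen at this place would help to separate the two. Going by these compounds, whether fluoro, methoxy or an amine here would give stronger or weaker inhibition also remains open.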